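The source may report more compounds than this note shows. Statements on the series, on what has been measured and on what is new or still open speak of the compounds shown alone.

Working notes on the series. The three measured compounds share one core and differ in the ester side chain and in how the stereocentres are drawn. In a functional assay (cardiac atrium) for agonist activity, with Cavia porcellus as the target (a lower number here means that less compound is needed, a higher number that more compound is needed for the effect), compound 1 `CC1=C(C(=O)OCCO[N+](=O)[O-])C(c2cccc3nonc23)C([N+](=O)[O-])=C(C)C1` gives 31100 nM. Compound 2 `CC1=C(C(=O)O[C@@H](C)CO[N+](=O)[O-])[C@H](c2cccc3nonc23)C([N+](=O)[O-])=C(C)C1` gives 156 nM in this assay, the lowest number of the three. Compound 3 `CC1=C(C(=O)OC(C)CO[N+](=O)[O-])C(c2cccc3nonc23)C([N+](=O)[O-])=C(C)C1` gives 1860 nM in this assay.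

From compound 3 to compound 1 the change is hydrogen in place of methyl on a saturated chain carbon bound to an oxygen next to a carbonyl group and a saturated chain carbon, and the step is a 17-fold higher number from compound 3 to compound 1 (1.22 log units; beyond the scatter). Compound 2 and compound 3 have the same atoms and bonds; the cores differ as the two compounds have the same atoms and bonds; at least one stereo element is drawn with a configuration in one of them and without one in the other: 2 of 2 stereo elements differ; a stereocentre at a saturated chain carbon is drawn without a configuration in compound 3 and S in compound 2; a stereocentre at a saturated ring carbon is drawn without a configuration in compound 3 and S in compound 2, and the step is a 12-fold higher number from compound 2 to compound 3 (1.08 log units; beyond the scatter), which is consistent with the fact that one of compounds 2 and 3 is drawn with a defined configuration and the other without, at the place where they differ.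

Compound 4 `CC1=C(C(=O)OCCO[N+](=O)[O-])[C@H](c2cccc3nonc23)C([N+](=O)[O-])=C(C)C1` is not yet measured. From compound 2 it differs by hydrogen in place of methyl on a saturated chain carbon bound to an oxygen next to a carbonyl group and a saturated chain carbon, the same change as from compound 3 to compound 1, at the same place. Since that earlier step was a 17-fold higher number from compound 3 to compound 1 (1.22 log units; beyond the scatter), a step of comparable size, perhaps somewhat smaller, is expected from compound 2 to compound 4, a 32-fold higher number from compound 2 to compound 4 (1.51 log units; beyond the scatter). Compound 4 is therefore estimated at 5000 nM in this assay, expected between 1500 nM and 18000 nM.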

Compound 4, half-maximal effective concentration: 3130 nM
Compound 4: the middle estimate sits 1.6-fold (0.20 log units) above what was measured; low and high end bracket the measured number.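

In this assay, hydrogen in place of methyl on a saturated chain carbon bound to an oxygen next to a carbonyl group and a saturated chain carbon gives a 20-fold higher number from compound 2 to compound 4 (1.30 log units; beyond the scatter), and this step agrees with the earlier one: the same change on two cores in this assay, a 17-fold higher number (1.22 log units; beyond the scatter) from compound 3 to compound 1 and a 20-fold higher number (1.30 log units; beyond the scatter) from compound 2 to compound 4, 1.2-fold (0.08 log units) apart, within the scatter of two such steps. The change therefore carries over between these two cores with its size kept, while the ring stereocentre alone, with the chain unchanged, goes with a 9.9-fold lower number from compound 1 to compound 4 (1.00 log units; beyond the scatter): the fact that one of compounds 1 and 4 is drawn with a defined configuration and the other without, at the place where they differ. This rests on two pairs whose cores have the same atoms and bonds and differ only in how a stereocentre is drawn, so it shows nothing about a core with different atoms and does not explain why the methyl matters.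

The compounds shown leave open how an ethyl group or a longer chain on that saturated chain carbon would compare with methyl and hydrogen. They also leave open how the R configuration at either stereocentre would read in this assay.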